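Nitro in place of fluoro: one step, two settings

A few compounds are considered here, and "the series" means these few. Any claim that something is new, unique, unknown or untested is made for them only; others in the source may bear on it.

Compound 2 `COC(=O)c1ccc(CN(CCCc2c(N)nc(N)nc2O)c2cc(F)c(F)cc2[N+](=O)[O-])cc1` and compound 1 `COC(=O)c1ccc(CN(CCCc2c(N)nc(N)nc2O)c2cc(F)c([N+](=O)[O-])cc2[N+](=O)[O-])cc1` share a core. In a functional assay on CCRF-CEM cells (Homo sapiens) for cytotoxicity, in the absence of a further agent (a higher number here means a weaker inhibitor, a lower number a stronger inhibitor), compound 2 gives 55000 nM, while compound 1 gives 3900 nM. The change is nitro in place of fluoro on an aromatic carbon, and it made the step of a 14-fold lower number from compound 2 to compound 1 (1.15 log units; beyond the scatter). Compound 3 `Nc1nc(N)c(CCCN(Cc2ccc(NC(CCC(=O)O)C(=O)O)cc2)c2ccc([N+](=O)[O-])c(F)c2F)c(O)n1` sits at a limit of this assay rather than a number: > 100000 nM, as noted in the limit of > 100000 nM in this assay, at which 1 of the 3 values shown sits. How the core of compound 3 differs from that of compound 2 is not broken down here. Compound 4 `Nc1nc(N)c(CCCN(Cc2ccc(NC(CCC(=O)O)C(=O)O)cc2)c2ccc([N+](=O)[O-])c(F)c2[N+](=O)[O-])c(O)n1` carries the same kind of change, (nitro in place of fluoro on an aromatic carbon); the surroundings are not the same, since the earlier change sits para to a large group and this one ortho to a large group. A step of an at least 5.0-fold lower number from compound 3 to compound 4 (0.69 log units; beyond the scatter) is expected, resting on a 14-fold lower number from compound 2 to compound 1 (1.15 log units; beyond the scatter). Compound 4 is estimated at 20000 nM, between 3000 nM and 150000 nM.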

Compound 4, half-maximal inhibitory concentration: 48000 nM
Estimate against measurement, compound 4: 2.4-fold (0.38 log units) below; low and high end bracket the measured number.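

On the second core the nitro-for-fluoro change again gives an at least 2.0-fold lower number from compound 3 to compound 4 (0.31 log units; beyond the scatter) in this assay. The direction of the step is thus shared by the two cores, though the two sizes cannot be set against each other: the same change on two cores in this assay, a 14-fold lower number (1.15 log units; beyond the scatter) from compound 2 to compound 1 and an at least 2.0-fold lower number (0.31 log units; beyond the scatter) from compound 3 to compound 4; the limit leaves it open whether they differ. On these data alone, compound 3 stands at > 100000 nM, which is a limit and not a number, so the true size of the step on this core remains unknown, and two pairs cannot establish a rule for the series.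

As far as these compounds go, whether a chloro group or an amine in the same place would shift the number in the same direction remains open. So does the size of the step on a core whose fluoro starting compound gives a measurable number.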